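Compound 4: An Ether in Place of the Amine

The source may report more compounds than this note shows. Statements on the series, on what has been measured and on what is new or still open speak of the compounds shown alone.

Measured compounds:
compound 1, `CCCCN(CC)c1nc(C)nc2c1nnn2-c1ccc(N(C)C)cc1C(F)(F)F`: 15.4 nM
compound 2, `CCN(CC)c1nc(C)nc2c1ncn2-c1ccc(C(C)C)cc1Br`: 12.4 nM
compound 3, `CCCCN(CC)c1nc(C)nc2c1nc(-c1ccccc1)n2-c1c(Cl)cc(OC)cc1OC`: 133 nM

In an in vitro assay on 293-EBNA cells for binding affinity to corticotropin-releasing factor receptor 1 (Homo sapiens) (on this read-out higher numbers stand for weaker inhibition and lower numbers for stronger inhibition), compound 2 gives 12.4 nM, the lowest of the three numbers. Compound 1 lies within the usual scatter of it, so the two cannot be ranked against each other. Compound 3 stands clearly apart, with a number beyond the scatter of compound 2, so compound 2 binds more tightly than compound 3.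

Compound 4, `CCC(COC)Oc1nc(C)nc2c1ncn2-c1ccc(C(C)C)cc1Br`, has not been measured in this assay. It differs from compound 2 in one place: 1-(methoxymethyl)propoxy in place of diethylamino on an aromatic carbon. Among the measured compounds shown here, no pair of measured compounds shows the effect of this exchange, so the expectation rests only on the shared core and the unchanged aryl group of compound 2. Compound 4 is expected to weaken somewhat, by a step of a 2.0-fold higher number from compound 2 to compound 4 (0.30 log units; within the scatter) that may or may not exceed the scatter. Compound 4 is therefore estimated at 25 nM, in a range from 6 nM to 100 nM.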

Compound 4, inhibition constant: 9.7 nM
Compound 4: middle estimate off by 2.6-fold (0.41 log units), on the high side, within the range that was stated.
By their numbers in this assay, from the lowest: compounds 4, 2 and 1 (each within the scatter of the next); then compound 3.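

At this position, on an aromatic carbon next to the ring nitrogen, 1-(methoxymethyl)propoxy takes the place of diethylamino with the rest of compound 2 unchanged, and this assay gives a 1.3-fold lower number from compound 2 to compound 4 (0.11 log units; within the scatter), so the two compounds cannot be ranked against each other. For this pair, then, an amine on this carbon is not needed for a value in the range of compound 2, and the larger ether chain, with its two oxygens, is accepted there. Nothing available accounts for the two groups reading alike.

The compounds shown leave open which part of the ether chain matters, since a simple methoxy or ethoxy group on this carbon does not appear among them. They also leave open whether the same exchange would read alike with another aryl group, such as a dimethylamino-substituted one.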